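A few compounds are considered here, and "the series" means these few. Any claim that something is new, unique, unknown or untested is made for them only; others in the source may bear on it.

Working notes on the series.

Going by the values given here, compound 3 `COc1cc(Cl)cc(-c2nn(-c3cccc(NC(=O)Nc4ccc(Cl)c(Cl)c4)c3)cc2-c2ccncc2)c1` gives -7% in a functional assay on MOLT-4 cells (Homo sapiens) for inhibition, read by sulforhodamine B assay, with a stated time of 48 h, tested at 100 uM (a lower number here means a stronger effect, a higher number a weaker effect of the compound at the concentration tested), which stands as the highest of the three numbers measured so far. Its nearest neighbour is compound 2 `O=C(Nc1cccc(-n2cc(-c3ccncc3)c(-c3cc(O)cc(Cl)c3)n2)c1)Nc1ccc(Cl)c(Cl)c1`, which gives -10% in this assay, within the scatter of compound 3, while compound 1 `O=C(Nc1cccc(-n2cc(-c3ccncc3)c(-c3cc(O)cc(Cl)c3)n2)c1)Nc1ccc(Cl)c(C(F)(F)F)c1` lies furthest away with -39% in this assay, beyond the scatter. Among the measured steps, a number 29 percentage points higher from compound 1 to compound 2 (beyond the scatter) and a number 3 percentage points higher from compound 2 to compound 3 (within the scatter).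

Compound 4 `COc1cc(Cl)cc(-c2nn(-c3cccc(NC(=O)c4cccc(C(F)(F)F)c4)c3)cc2-c2ccncc2)c1` is the next to be measured. It differs from compound 3 in one place: 3-(trifluoromethyl)phenyl in place of (3,4-dichlorophenyl)amino on a carbonyl carbon. Among the compounds with values here, no measured step covers this change directly, since it removes the amide-type nitrogen of the leaving group as well as swapping the halogens for a trifluoromethyl; only the step from compound 1 to compound 2 touches the trifluoromethyl-for-chloro exchange, and it was modest and beyond the scatter, in the direction of a lower number when trifluoromethyl is present. Compound 4 is therefore expected to move by about a number 13 percentage points lower from compound 3 to compound 4 (beyond the scatter), with wide uncertainty. For compound 4 the estimate in this assay is -20%, within the range from -50% to 5%.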

Compound 4, a percentage reported as activity, at one concentration (the size of the read-out at that concentration, not a potency): 27%
Estimate against measurement, compound 4: 47 percentage points below, outside the stated range (above it).
By their numbers in this assay, from the lowest: compound 1; then compounds 2 and 3 (each within the scatter of the next); then compound 4.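

Going by these compounds alone, on a carbonyl carbon, 3-(trifluoromethyl)phenyl in place of (3,4-dichlorophenyl)amino gives a number 34 percentage points higher from compound 3 to compound 4 (beyond the scatter) in this assay and is the only step so far printed as large, so this position carries more of the read-out than the earlier single changes showed. The change removes the amide-type nitrogen and both chlorines together, so the step cannot be assigned to either part alone. No measurement of a property bears on this result.

Still open, from the compounds shown here alone, is whether a 3,4-dichlorophenyl group set directly on the carbonyl carbon, or a 3-(trifluoromethyl)phenylamino group, would follow compound 3 or compound 4 in this read-out. Also open, going by these compounds, is how a methylene in place of the amide-type nitrogen, or an amine or carboxylic acid on the same ring, would behave at this position.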